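The source may hold more compounds than are shown below. What is called first, only, known or untested is meant among the compounds shown, and "the series" means these compounds.

Among the measured compounds shown here, compound 1 `O=[N+]([O-])c1ccc(-c2nc(CO[C@@H]3O[C@H](CO)[C@H]4OC5(CCCC5)O[C@@H]34)no2)cc1` stands lowest of the two numbers so far obtained in a functional assay on SW1573 cells (Homo sapiens) for antiproliferative activity, read by sulforhodamine B assay, with a stated time of 48 h (on this read-out lower numbers stand for stronger inhibition of growth and higher numbers for weaker inhibition of growth), where compound 1 gives 27000 nM. The nearest of the others is compound 3 `CC1(C)O[C@H]2[C@H](OCc3noc(-c4ccc([N+](=O)[O-])cc4)n3)O[C@H](CO)[C@H]2O1`, which in this assay gives 60000 nM, a gap that lies beyond the scatter. Compound 2 `CC1(C)O[C@H]2[C@H](OCc3noc(-c4ccc([N+](=O)[O-])cc4)n3)O[C@H](CSc3ncn[nH]3)[C@H]2O1` in this assay returns > 100000 nM, which is a limit of the assay and not a number. For the measured compounds named here, the only step between two measured compounds that differ in one place, an at least 1.6-fold lower number from compound 2 to compound 3 (0.22 log units; that floor lies within the scatter), therefore rests on (the limit of > 100000 nM in this assay, at which 1 of the 3 values shown sits).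

Compound 4 `Cc1ccc(S(=O)(=O)OC[C@H]2O[C@@H](OCc3noc(-c4ccc([N+](=O)[O-])cc4)n3)[C@@H]3OC4(CCCC4)O[C@@H]32)cc1` has not been measured. Compared with compound 1 the change is (4-methylphenyl)sulfonyl in place of hydrogen on an oxygen on a saturated carbon. Going by the values given here, no measured pair tests a sulfonyl group on that oxygen. The step of an at least 1.6-fold lower number from compound 2 to compound 3 (0.22 log units; that floor lies within the scatter) is the only one touching the hydroxymethyl of the shared core, and there the larger group in place of hydroxy gave the higher number, although its floor lies within the scatter. A modest rise is expected in this assay for compound 4, not clearly beyond the scatter, and the expected step is a 1.5-fold higher number from compound 1 to compound 4 (0.17 log units; within the scatter). Compound 4 is thus estimated to give 40000 nM, in a range from 12000 nM to 100000 nM.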

Compound 4, concentration for 50% growth inhibition: > 100000 nM
Compound 4: only a limit was reported; the forecaster's own chance of this, stated with the estimate: 25%; middle value at least 2.5-fold (0.39 log units) from the limit.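

In this assay compound 4 gives > 100000 nM, which is a limit of the assay and not a number. Placing (4-methylphenyl)sulfonyl on the oxygen of the hydroxymethyl of compound 1 gives an at least 3.7-fold higher number from compound 1 to compound 4 (0.56 log units; beyond the scatter), so this position now has a step that clearly exceeds the scatter, which the earlier step on the same hydroxymethyl, an at least 1.6-fold lower number from compound 2 to compound 3 (0.22 log units; that floor lies within the scatter), could not show. The two compounds shown with a larger group in place of the hydroxy, compound 2 and compound 4, both end at the limit, so the size of this step is only a floor and the comparison rests on the following: the limit of > 100000 nM in this assay, at which 2 of the 4 values shown sit.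

The compounds shown leave open whether the rise follows from the (4-methylphenyl)sulfonyl group itself or from any replacement of the free hydroxy, a question that a methyl ether on that oxygen or an amine in place of the hydroxy would help to separate. They also leave open how far the step extends, and whether a smaller group at this position would keep the growth inhibition seen with compound 1.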